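The source may report more compounds than this note shows. Statements on the series, on what has been measured and on what is new or still open speak of the compounds shown alone.

Measured so far in an ADME assay on the whole organism with Oryza sativa as the target, tested at 0.1 uM; on this read-out lower numbers stand for a stronger effect and higher numbers for a weaker effect at the one concentration tested:
compound 1, `CCCCCc1ccc(NC(=O)N[C@@H](C)c2ccccc2)cc1`, gives 98%
compound 2, `C[C@H](NC(=O)Nc1ccc(F)cc1)c1ccccc1`, gives 96%
compound 3, `C[C@H](NC(=O)Nc1ccc(I)cc1)c1ccccc1`, gives 99%

Compound 2 stands lowest of the three numbers in this assay, but its distances to the others are small: a number 2 percentage points lower from compound 1 to compound 2 (within the scatter) and a number 3 percentage points higher from compound 2 to compound 3 (within the scatter), both within the scatter, as is a number 1 percentage points higher from compound 1 to compound 3 (within the scatter). Nothing therefore separates the three compounds on this read-out.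

The next compound, compound 4, `C[C@H](NC(=O)Nc1ccc(F)cc1F)c1ccccc1`, differs from compound 2 by fluoro in place of hydrogen on an aromatic carbon. The measured steps that bear on it are the three changes on an aromatic carbon of the shared core: pentyl to fluoro, pentyl to iodo and fluoro to iodo, each within the scatter. Those steps swap one group for another, whereas here a fluoro enters where a hydrogen stood, so the precedent is indirect. Still, with every measured step flat and all three numbers sitting close together, no step beyond the scatter is expected, and the step from compound 2 to compound 4 is estimated as no change at the digits printed from compound 2 to compound 4 (within the scatter). Compound 4 is accordingly expected to give 96% in this assay, with a range from 86% to 100%.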

Compound 4, a percentage reported as activity, at one concentration (the size of the read-out at that concentration, not a potency): 101%
Compound 4: middle estimate off by 5 percentage points, on the low side; the measured number lies above the stated range.
By their numbers in this assay, from the lowest: compounds 2, 1, 3 and 4 (each within the scatter of the next).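

In this assay, the fluoro group entering ortho to a large group and meta to a fluoro group gives a number 5 percentage points higher from compound 2 to compound 4 (within the scatter) and so stays within the scatter. Among these compounds, the earlier steps all exchanged one group for another at a single place, whereas this step is the first to fill an aromatic carbon that bears hydrogen in compound 1, compound 2 and compound 3, and it shows that a single fluoro on this carbon leaves the read-out within the scatter of compound 2. No measurement at hand bears on the reason for this result.

Among the compounds shown, this carbon carries only hydrogen or fluoro, so it remains open whether a larger or differently built group here, such as a methoxy group, an amine or a carboxylic acid, would give a step beyond the scatter. Also open is whether any change outside the aromatic ring that carries these groups would separate the series on this read-out, since all four compounds shown keep the rest of the shared core unchanged.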